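A few compounds are considered here, and "the series" means these few. Any claim that something is new, unique, unknown or untested is made for them only; others in the source may bear on it.

Working notes on the series in a functional assay on MCF7 cells (Homo sapiens) for cytotoxicity, read by MTT assay, with a stated time of 72 h, tested at 30 uM; on this read-out lower numbers stand for less inhibition of growth and higher numbers for more inhibition of growth at the one concentration tested.

Compound 1 `N/C(=N\NC(=S)N1CCOCC1)c1ccccn1` gives 78.1% in this assay. Compound 2 `Cc1cccc(/C(N)=N/NC(=S)N2CCOCC2)n1` gives 57.8%, and compound 3 `Cc1ccnc(/C(N)=N/NC(=S)N2CCCCCC2)c1` gives 75.9%. Compound 2 thus stands lowest of the three measured numbers; its gap to compound 3 and to compound 1 both lie beyond the scatter. Within the data shown here, the one step that joins two measured compounds in one place is a number 20.3 percentage points lower from compound 1 to compound 2 (beyond the scatter), a methyl in place of hydrogen on an aromatic carbon.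

Compound 4 `Cc1cccc(/C(N)=N/NC(=S)N2CCCC2)n1` has not been measured. It differs from compound 2 by pyrrolidin-1-yl in place of morpholin-4-yl on a thiocarbonyl carbon. Among the measured compounds shown here, no measured pair differs only at the ring on the thiocarbonyl carbon, so no measured step bears on this change; compound 3 carries a different ring there but also places its methyl elsewhere, so its value and that of compound 2 can only be set side by side, not read as a step. For compound 4 the expected step is therefore small, a number 4.2 percentage points higher from compound 2 to compound 4 (within the scatter), within or near the scatter, and the estimate for compound 4 is 62% with a range from 45% to 80%.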

Compound 4, percent growth inhibition at one concentration: 40.1%
The estimate for compound 4 lay 21.9 percentage points above the measured number, and the stated range ends above it.
By their numbers in this assay, from the lowest: compound 4; then compound 2; then compounds 3 and 1 (each within the scatter of the next).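

In this assay, among these compounds, pyrrolidin-1-yl in place of morpholin-4-yl on a thiocarbonyl carbon gives a number 17.7 percentage points lower from compound 2 to compound 4 (beyond the scatter), the only measured step at this position, so the ring on that carbon does affect the read-out. The change alters ring size and removes the ring oxygen at once, and the two compounds cannot separate these differences. No measurement at hand bears on the reason for the lower number.

Open, as far as these compounds go, is whether piperidin-1-yl, a six-membered ring without the oxygen, would stand nearer compound 2 or nearer compound 4, which would help separate ring size from the oxygen. Also open, from the compounds shown here alone, is whether the same exchange gives a similar step on the core of compound 1, since compound 3 differs from compound 2 in more than one place and cannot settle this.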